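Compound 2 to compound 4: a change of chain and ring

A few compounds are considered here, and "the series" means these few. Any claim that something is new, unique, unknown or untested is made for them only; others in the source may bear on it.

Measured so far in an ADME assay on HEK293 cells (Homo sapiens) for cytotoxicity, read by MTT assay, with a stated time of 48 h; a lower number here means a stronger inhibitor, a higher number a weaker inhibitor
compound 1 `CCN(CC)CCn1c(N)c(-c2nc3ccccc3[nH]2)c2nc(C#N)c(C#N)nc21` gives 12200 nM
compound 2 `CN1CCN(CCn2c(N)c(-c3nc4ccccc4[nH]3)c3nc(C#N)c(C#N)nc32)CC1` gives 10900 nM
compound 3 `CCCCn1c(N)c(-c2nc3ccccc3[nH]2)c2nc(C#N)c(C#N)nc21` gives > 50000 nM as a limit of the assay, not a number

Within the data shown here, compound 2 is not separated from compound 1 beyond the scatter, and together they hold the only two numbers. The change to compound 4 `N#Cc1nc2c(-c3nc4ccccc4[nH]3)c(N)n(CCCN3CCCCC3)c2nc1C#N` is (piperidin-1-yl)methyl in place of 4-methylpiperazin-1-yl on a saturated chain carbon, two bonds along the chain from an aromatic nitrogen with (piperidin-1-yl)methyl in place of 4-methylpiperazin-1-yl on a saturated chain carbon, two bonds along the chain from an aromatic nitrogen. Among the measured compounds shown here, three measured steps bear on it. Diethylamino to 4-methylpiperazin-1-yl (a 1.1-fold lower number from compound 1 to compound 2 (0.05 log units; within the scatter)) stayed within the scatter. Ethyl in place of either group (an at least 4.0-fold higher number from compound 1 to compound 3 (0.61 log units; beyond the scatter) and an at least 4.5-fold higher number from compound 2 to compound 3 (0.66 log units; beyond the scatter)) went beyond it, towards a higher number. Compound 4 carries no such ethyl, so the first step is taken as the nearer guide, and no step beyond the scatter is expected in this assay. For compound 4 the estimated step is (a 1.1-fold lower number from compound 2 to compound 4 (0.04 log units; within the scatter)) on that reading. Compound 4 is expected at 10000 nM within an estimated range of 4500 nM to 24000 nM in this series.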

Compound 4, half-maximal inhibitory concentration: 6720 nM
Compound 4: middle estimate off by 1.5-fold (0.17 log units), on the high side, within the range that was stated.
By their numbers in this assay, from the lowest: compounds 4, 2 and 1 (each within the scatter of the next). At a limit, above all of these: compound 3.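

In this assay, going from 2-(4-methylpiperazin-1-yl)ethyl to 3-(piperidin-1-yl)propyl changes both chain and ring, yet a 1.6-fold lower number from compound 2 to compound 4 (0.21 log units; within the scatter) stays within the scatter, as does a 1.8-fold lower number from compound 1 to compound 4 (0.26 log units; within the scatter), so this position accepts both changes together without a readable shift. The divide seen earlier now holds for a third compound: an at least 7.4-fold lower number from compound 3 to compound 4 (0.87 log units; beyond the scatter) goes beyond the scatter, and compounds 1, 2 and 4, each with a ring or chain amine at the chain end, all give numbers. Compound 3 stands at a limit, not a number: the limit of > 50000 nM in this assay, at which 1 of the 4 values shown sits.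

The chain and ring changes in compound 4 remain inseparable, and a 2-(piperidin-1-yl)ethyl group would pull them apart. Also open, as far as these compounds go, is how a morpholin-4-yl group or a carboxylic acid at the chain end would read here.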